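The compounds below may be only part of what the source reports. "The series", "measured", "known", "first", "only" and "open" are said of these compounds alone.

Measured so far:
- Compound 1, `CCCN1CC[C@@]2(OC)OC(N)=C(C#N)[C@@H](c3ccc(Br)cc3)[C@@H]2C1`: 19400 nM
- Compound 2, `CO[C@@]12CCN(C)C[C@H]1[C@H](c1ccc(Cl)cc1Cl)C(C#N)=C(N)O2`: 14900 nM

Both compounds were tested in a functional assay on trachea (Cavia porcellus); a lower number here means a stronger inhibitor, a higher number a weaker inhibitor. Compound 1, `CCCN1CC[C@@]2(OC)OC(N)=C(C#N)[C@@H](c3ccc(Br)cc3)[C@@H]2C1`, gives 19400 nM in this assay. Compound 2, `CO[C@@]12CCN(C)C[C@H]1[C@H](c1ccc(Cl)cc1Cl)C(C#N)=C(N)O2`, gives 14900 nM in this assay. The two numbers lie within the usual scatter of each other, so nothing can be said about which of the two is the stronger inhibitor; both are weak.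

Compound 3, `CCCN1CC[C@@]2(OC)OC(N)=C(C#N)[C@@H](c3ccc(Cl)cc3Cl)[C@@H]2C1`, has not yet been measured. It differs from compound 2 in one place: ethyl in place of hydrogen on a saturated chain carbon bound to an amine nitrogen in a ring. Compound 1 carries the same propyl chain but a different aryl group, and its number in this assay sits close to that of compound 2. Going by the values given here, no measured pair here isolates this change alone, so the step from compound 2 to compound 3 is expected to be small, likely none beyond the scatter, with a 1.1-fold lower number from compound 2 to compound 3 (0.06 log units; within the scatter) as the working guess. Compound 3 is therefore estimated at 13000 nM, within a range of 5000 nM to 35000 nM.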

Compound 3, half-maximal inhibitory concentration: 35500 nM
Estimate against measurement, compound 3: 2.7-fold (0.44 log units) below; the measured number lies above the stated range.
By their numbers in this assay, from the lowest: compounds 2, 1 and 3 (each within the scatter of the next, the first and the last beyond it).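

In this assay, ethyl in place of hydrogen on a saturated chain carbon bound to an amine nitrogen in a ring, which turns methyl into propyl, gives a 2.4-fold higher number from compound 2 to compound 3 (0.38 log units; beyond the scatter) with the aryl group unchanged. Going by these compounds alone, this is the first reading of that change on its own, and it shows a modest loss of strength. With the propyl chain kept, 2,4-dichlorophenyl in place of 4-bromophenyl on a saturated ring carbon gives a 1.8-fold higher number from compound 1 to compound 3 (0.26 log units; within the scatter) and so does not separate the two aryl groups. Nothing at hand accounts for the weakening seen with the longer chain.

From the compounds shown here alone, whether a still longer chain such as butyl, or a benzyl group, would weaken the compound further remains open. So does whether the methyl-to-propyl step would be the same with 4-bromophenyl as the aryl group.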